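Thiophen-2-yl in place of iodo: tolerance notes

The source may hold more compounds than are shown below. What is called first, only, known or untested is meant among the compounds shown, and "the series" means these compounds.

Measured so far:
compound 1 `Cc1cc(-c2cccc(O)c2)c2ncc(CSCCc3ccccc3)n2c1` — 20 ug/mL
compound 2 `Cc1cc(I)c2ncc(CSCCc3ccccc3)n2c1` — >= 4 ug/mL

In an ADME assay on HEL cells (Homo sapiens) for cytotoxicity, with a stated time of 3 days (a higher number here means that more compound is tolerated, a lower number that less compound is tolerated), compound 1 gives 20 ug/mL. For compound 2 only a limit is known, >= 4 ug/mL; this is the limit of >= 4 ug/mL in this assay, at which 1 of the 2 values shown sits, not a number. The step that the limit leaves unreadable from compound 1 to compound 2 is consequently unreadable in size and direction.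

Compound 3 `Cc1cc(-c2cccs2)c2ncc(CSCCc3ccccc3)n2c1` is not yet measured. It differs from compound 2 by thiophen-2-yl in place of iodo on an aromatic carbon. Going by the values given here, no measured step carries this same exchange, and the one measured step, iodo in place of 3-hydroxyphenyl, cannot be read because of the limit of >= 4 ug/mL in this assay, at which 1 of the 2 values shown sits. What remains is that compound 1, which also carries an aromatic ring at this position, gives 20 ug/mL. For compound 2 only a limit is known.

Compound 3 is therefore expected around 20 ug/mL, within 5 ug/mL to 80 ug/mL. The step that the limit leaves unreadable from compound 2 to compound 3 so expected starts from a limit and its size cannot be judged against the scatter.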

Compound 3, minimum cytotoxic concentration: 100 ug/mL
Compound 3: the middle estimate sits 5.0-fold (0.70 log units) below what was measured, outside the stated range (above it).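

In this assay, exchange of 3-hydroxyphenyl for thiophen-2-yl on this aromatic carbon gives a 5.0-fold higher number from compound 1 to compound 3 (0.70 log units; beyond the scatter). Going by these compounds alone, this is the first readable step at the position, and it shows that the two aromatic rings are not interchangeable here, with compound 3 tolerated at the higher concentration. Compound 2 carries a limit, not a number, so neither step involving it can be read and iodo cannot be ranked against either ring: the limit of >= 4 ug/mL in this assay, at which 1 of the 3 values shown sits.

Open is whether the difference between compound 1 and compound 3 follows the five-membered sulfur ring or the hydroxyl group, since a plain phenyl is not among the compounds shown. Also open, on these data alone, is how a furan-2-yl ring, an amine or a carboxylic acid at this position would read in this assay.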